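Solubility in a Quinoline Series: Replacing a Benzyl Group

This account rests on a few compounds, and the source may have more. Where it says the series, first, only, none or still open, it means among the compounds named here.

Compound 1 `COc1ccc(F)cc1CNCCCNc1ccnc2cc(Cc3ccc(F)cc3)ccc12` is the starting point. In a physicochemical assay for solubility, with a stated time of 18 h, at pH 7.4 (on this read-out lower numbers stand for lower solubility and higher numbers for higher solubility), compound 1 gives 4200 nM. Compound 2 `Fc1ccc(Cc2ccc3c(NCCCNCc4ccco4)ccnc3c2)cc1` gives 4200 nM in this assay, and compound 3 `COc1cccc(CNCCCNc2ccnc3cc(-c4cccc5ccccc45)ccc23)c1O` gives 32000 nM. Compound 1 therefore stands level with compound 2, the two together being the lowest of the three numbers, while compound 3 lies well above both.

Going by the values given here, only one measured step connects two compounds that differ in a single place: no change at the digits printed from compound 1 to compound 2 (within the scatter). That step changes the group on the saturated chain carbon bound to an amine nitrogen, a different part of the molecule from the one altered here.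

Compound 4 `COc1ccc(F)cc1CNCCCNc1ccnc2cc(Oc3ccccc3)ccc12` differs from compound 1 as follows: phenoxy in place of 4-fluorobenzyl on an aromatic carbon. No measured step touches this aromatic carbon in isolation, so the change has no direct precedent among these compounds. Compound 3 carries a different group at that position but also a different benzylamine end, so its higher number cannot be attributed to either change alone. Among the compounds with values here, the one single-point step seen, from compound 1 to compound 2, gave no change, and nothing here points to a large shift in either direction.

The step from compound 1 to compound 4 is therefore expected to be small, a 1.4-fold higher number from compound 1 to compound 4 (0.15 log units; within the scatter). For compound 4 the solubility in this assay is estimated at 6000 nM, with a range from 2000 nM to 18000 nM.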

Compound 4, solubility: 14500 nM
Compound 4: middle estimate off by 2.4-fold (0.38 log units), on the low side; the measured number falls inside the stated range.
By their numbers in this assay, from the lowest: compounds 1 and 2 (each within the scatter of the next); then compound 4; then compound 3.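

Replacing 4-fluorobenzyl with phenoxy on this aromatic carbon is the first change among these compounds made at this position alone, and in this assay it gives a 3.5-fold higher number from compound 1 to compound 4 (0.54 log units; beyond the scatter) as a step that clears the usual scatter of repeated measurements. Going by these compounds alone, the only other single-place step, on the saturated chain carbon bound to an amine nitrogen, gives no change at the digits printed from compound 1 to compound 2 (within the scatter) and so leaves the number where it was, which makes this aromatic carbon the only one of the two changed places where the read-out has moved. The entering phenoxy has one hydrogen-bond acceptor where 4-fluorobenzyl has none, but no measurement available here explains the rise in solubility.

The swap replaces the carbon link to the outer ring with an oxygen and also removes the fluorine, so the compounds shown leave open which of these two differences goes with the higher number. A 4-fluorophenoxy group or a plain benzyl group on this carbon would pull the two apart, and an anilino group, with a nitrogen as the link, would test the link further.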